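Three Aryl Oxadiazoles With Little Growth Inhibition, a Fourth Estimated

This account rests on a few compounds, and the source may have more. Where it says the series, first, only, none or still open, it means among the compounds named here.

Compound 1 `CS(=O)(=O)c1ccc(-c2cnc3[nH]cc(-c4nnc(-c5ccc(Cl)cc5)o4)c(=O)c3c2)cc1`: 2.15%
Compound 2 `CS(=O)(=O)c1ccc(-c2cnc3[nH]cc(-c4nnc(-c5ccc(F)cc5)o4)c(=O)c3c2)cc1`: 2.55%
Compound 3 `Cc1ccc(-c2nnc(-c3c[nH]c4ncc(-c5ccc(S(C)(=O)=O)cc5)cc4c3=O)o2)cc1`: 0.43%

In a functional assay on KB cells (Homo sapiens) for inhibition, read by MTT assay, with a stated time of 24 h, tested at 5 uM (a higher number here means more inhibition of growth at the concentration tested, a lower number less inhibition of growth), compound 1 gives 2.15%, which is the second highest of the three numbers; its nearest neighbour is compound 2 a number 0.4 percentage points higher from compound 1 to compound 2 (within the scatter), and its furthest is compound 3 a number 1.7 percentage points lower from compound 1 to compound 3 (within the scatter). All three numbers thus sit together within the scatter, and none of the compounds can be called more or less active than another.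

Compound 4 `Cc1cccc(-c2nnc(-c3c[nH]c4ncc(-c5ccc(S(C)(=O)=O)cc5)cc4c3=O)o2)c1` differs from compound 1 by 3-methylphenyl in place of 4-chlorophenyl on an aromatic carbon. Going by the values given here, the one step that bears on this is the swap of methyl for chloro on the same aromatic ring, a number 1.7 percentage points lower from compound 1 to compound 3 (within the scatter), which stayed within the scatter; the step of a number 2.1 percentage points lower from compound 2 to compound 3 (within the scatter) likewise did. No step beyond the scatter is therefore expected in this assay, and compound 4 is estimated to give 1.5% (range -4% to 7%), a change of a number 0.7 percentage points lower from compound 1 to compound 4 (within the scatter) expected to lie within the scatter.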

Compound 4, percent growth inhibition at one concentration: 3.7%
Estimate against measurement, compound 4: 2.2 percentage points below; the measured number falls inside the stated range.
By their numbers in this assay, from the lowest: compounds 3, 1, 2 and 4 (each within the scatter of the next).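

Shifting the methyl group on the ring, the first change of position at this place, gives a number 3.3 percentage points higher from compound 3 to compound 4 (within the scatter) in this assay, so moving it does not separate the two compounds. Replacing the halogen-bearing rings with 3-methylphenyl gives a number 1.6 percentage points higher from compound 1 to compound 4 (within the scatter) and a number 1.2 percentage points higher from compound 2 to compound 4 (within the scatter), both also within the scatter, so all four aryl groups here remain indistinguishable. Nothing available explains this flat result. The compounds shown leave open whether an amine or a carboxylic acid on this phenyl ring would give a step beyond the scatter. They also leave open what a longer chain in place of the ring would do.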